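A few compounds are considered here, and "the series" means these few. Any claim that something is new, unique, unknown or untested is made for them only; others in the source may bear on it.

Measured compounds:
compound 1, `CCn1c(C(=O)N[C@H](CO)CCO)ccc1C(CC)(CC)c1ccc(OCS(=O)(=O)c2ccccc2)c(C)c1`, giving 28500 nM in a functional assay on MCF7 cells (Homo sapiens) for antiproliferative activity, read by MTT assay, with a stated time of 24 h; a lower number here means a stronger inhibitor, a higher number a weaker inhibitor
compound 2, `CCn1c(C(=O)N[C@H](CO)CCCO)ccc1C(CC)(CC)c1ccc(OCS(=O)(=O)c2ccccc2)c(C)c1`, giving 31400 nM in this assay

On these two numbers compound 2 holds the higher value, with compound 1 nearest; the step from one to the other, a 1.1-fold higher number from compound 1 to compound 2 (0.04 log units; within the scatter), lies within the scatter, so no order between the two can be read from it.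

Compound 3, `CCn1c(C(=O)N[C@H](CC(=O)O)C(=O)O)ccc1C(CC)(CC)c1ccc(OCS(=O)(=O)c2ccccc2)c(C)c1`, has not yet been measured in this assay. It differs from compound 2 at the amide-type nitrogen: a group of 8 heavy atoms (4 carbon, 4 oxygen; no ring) in place of a group of 7 heavy atoms (5 carbon, 2 oxygen; no ring), on an amide-type nitrogen.

Going by the values given here, the only step in hand, a 1.1-fold higher number from compound 1 to compound 2 (0.04 log units; within the scatter), concerns a change on the same side chain, a hydroxymethyl in place of a hydroxy, and it moved the number by nothing beyond the scatter. Among the compounds with values here, no measured compound carries a carboxylic acid on this chain, so the bearing of that step on compound 3 is indirect; it shows only that the chain tolerates a small change without a shift in this assay. Nothing supports a step beyond the scatter in either direction, and the range is set wide to cover that gap.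

Compound 3 is therefore expected to give 36000 nM, from 12000 nM to 110000 nM, which means an expected step of a 1.1-fold higher number from compound 2 to compound 3 (0.06 log units; within the scatter).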

Compound 3, half-maximal inhibitory concentration: > 50000 nM
Compound 3: no number, only a limit (the forecaster's own chance of this, stated with the estimate: 25%); at least 1.3-fold (0.14 log units) between middle value and limit.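

In this assay compound 3, carrying 1,2-dicarboxyethyl on the amide-type nitrogen, gives > 50000 nM, which is a limit of the assay and not a number. Going by these compounds alone, its steps, an at least 1.5-fold higher number from compound 2 to compound 3 (0.20 log units; that floor lies within the scatter) and an at least 1.7-fold higher number from compound 1 to compound 3 (0.24 log units; that floor lies within the scatter), are floors only, so this change at the position shows no step to a lower number, while the true size of any step to a higher number stays unknown. Where the two hydroxylated chains of the earlier compounds gave readable numbers, this chain is the first to reach the end of the readable range, and the series now has one compound without a number: the limit of > 50000 nM in this assay, at which 1 of the 3 values shown sits.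

The compounds shown leave open whether compound 3 truly separates from compound 2 and compound 1 beyond the scatter, since both floors lie within it. They also leave open how a chain with a single carboxylic acid, a methyl ester of the 1,2-dicarboxyethyl group, or an amine on the same amide-type nitrogen would read in this assay, so the result cannot yet be assigned to any one feature of the group.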